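A few compounds are considered here, and "the series" means these few. Any claim that something is new, unique, unknown or untested is made for them only; others in the source may bear on it.

Compound 1 `C[C@@H](NC(=O)NCc1ccc(C(C)(C)C)cc1)c1ccc(NS(C)(=O)=O)cc1` and compound 2 `C/C(=C\c1ccc(C(C)(C)C)cc1)C(=O)N[C@H](C)c1ccc(NS(C)(=O)=O)cc1` were both examined in an assay on isolated protein for agonist activity at transient receptor potential cation channel subfamily V member 1 (Rattus norvegicus), read by scintillation counting and calcium flux, with a stated time of 10 min, in the presence of a further agent that is not named here; on this read-out higher numbers stand for an effect only at larger amounts of compound and lower numbers for an effect already at smaller amounts. Compound 1 gives > 100000 nM, which is a limit of the assay rather than a number. Compound 2 likewise gives > 100000 nM, again only a limit. Compound 2 therefore stands at the limit of > 100000 nM in this assay, at which 2 of the 2 values shown sit, with no number of its own. Compound 3 `C=Cc1cc([C@@H](C)NC(=O)/C(C)=C/c2ccc(C(C)(C)C)cc2)ccc1NS(C)(=O)=O` carries vinyl in place of hydrogen on an aromatic carbon. Going by the values given here, no measured step between two compounds exists here, so the step from compound 2 to compound 3 a step that the limit leaves unreadable from compound 2 to compound 3 is expected to be none beyond the scatter, with the limit again the likely outcome. Compound 3 is accordingly estimated at 150000 nM, in a range from 30000 nM to 1000000 nM.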

Compound 3, half-maximal effective concentration: > 100000 nM
Compound 3 was reported as a limit; the forecaster's own chance of this, stated with the estimate: 85%; the middle value does not contradict the limit.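

No step can be read from compound 2 to compound 3, since both give only a limit of the assay: the limit of > 100000 nM in this assay, at which 3 of the 3 values shown sit.

The compounds shown leave open what effect, if any, vinyl in place of hydrogen on an aromatic carbon has.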